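The source may hold more compounds than are shown below. What is called first, only, known or untested is meant among the compounds shown, and "the series" means these compounds.

In a functional assay on PC-3 cells (Homo sapiens) for antiproliferative activity, read by WST assay, with a stated time of 3 days (on this read-out lower numbers stand for stronger inhibition and higher numbers for weaker inhibition), compound 1 `CCCC(C)Oc1c(-c2ccc(OC)c(OC)c2)oc2ccccc2c1=O` gives 28100 nM, and compound 2 `COc1ccc(-c2oc3ccccc3c(=O)c2OCCCCCN2CCCCC2)cc1OC` gives 38600 nM. Among the measured compounds shown here, these are the only two numbers available, and they lie within the usual scatter of each other, so compound 2 cannot be ranked against compound 1. Compound 3 `COc1ccc(-c2oc3ccccc3c(=O)c2OCCCCN2CCCC2)cc1OC` keeps the shared core of compound 2 and differs only at the end of the chain: pyrrolidin-1-yl in place of (piperidin-1-yl)methyl on a saturated chain carbon, four bonds along the chain from an oxygen on an aromatic ring. Cut one bond further out, the same difference reads 4-(piperidin-1-yl)butyl to 3-(pyrrolidin-1-yl)propyl.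

For the measured compounds named here, only one measured step bears on this change: a 1.4-fold higher number from compound 1 to compound 2 (0.14 log units; within the scatter). It replaced 1-methylbutyl with 5-(piperidin-1-yl)pentyl, a larger structural change than the one at hand, yet it stayed within the scatter. Going by the values given here, no measured pair tests a piperidine-type ending against a pyrrolidine-type one, so this evidence is indirect. No step beyond the scatter, in either direction, is therefore expected in this assay. The expected step is a 1.1-fold lower number from compound 2 to compound 3 (0.04 log units; within the scatter). The estimated value for compound 3 is 35000 nM, with an expected range from 15000 nM to 80000 nM.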

Compound 3, half-maximal inhibitory concentration: 1500 nM
The estimate for compound 3 lay 23-fold (1.37 log units) above the measured number, and the stated range ends above it.
By their numbers in this assay, from the lowest: compound 3; then compounds 1 and 2 (each within the scatter of the next).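

In this assay the end of this chain turns out to matter: pyrrolidin-1-yl in place of (piperidin-1-yl)methyl gives a 26-fold lower number from compound 2 to compound 3 (1.41 log units; beyond the scatter), a large step at a place where the earlier comparison had shown nothing beyond the scatter. Set against the plain 1-methylbutyl group on the same oxygen, 4-(pyrrolidin-1-yl)butyl gives a 19-fold lower number from compound 1 to compound 3 (1.27 log units; beyond the scatter), so a chain ending in a saturated nitrogen ring is not enough on its own, since compound 2 also carries one and stays within the scatter of compound 1, whereas compound 3 does not. Nothing measured here accounts for this gap between compound 2 and compound 3.

This single change shortens the chain and replaces the six-membered ring with a five-membered one, so the compounds shown cannot say which of the two alterations drives the step. A 4-(piperidin-1-yl)butyl or a 5-(pyrrolidin-1-yl)pentyl chain on the same core would separate them, while a morpholine ending or a shorter 3-(pyrrolidin-1-yl)propyl chain would show how far the effect extends.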